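Shortening the side chain from isopropyl to ethyl

This account rests on a few compounds, and the source may have more. Where it says the series, first, only, none or still open, it means among the compounds named here.

Compound 1 `CCOC(=O)NCc1cccc(-c2ccc(C(=O)N[C@H](C)[C@@H](Cc3cccc(C(=N)N)c3)C(=O)OC)cc2)c1` in an assay on isolated protein for inhibition of serine protease 1 (Homo sapiens) (on this read-out higher numbers stand for weaker inhibition and lower numbers for stronger inhibition), reaches only a limit of the assay, > 2900 nM. Compound 2 `COC(=O)[C@H](Cc1cccc(C(=N)N)c1)[C@@H](CC1CCCCC1)NC(=O)c1ccc(-c2cccc(CN)c2)cc1` in this assay gives 36 nM. Compound 3 `COC(=O)[C@H](Cc1cccc(C(=N)N)c1)[C@H](NC(=O)c1ccc(-c2cccc(CN)c2)cc1)C(C)C` in this assay gives 300 nM.

For the measured compounds named here, compound 3 holds the highest of the two numbers in this assay; the nearest is compound 2, and the one further value shown is a limit (the limit of > 2900 nM in this assay, at which 1 of the 3 values shown sits). Going by the values given here, the only measured step that touches the same side chain is an 8.3-fold higher number from compound 2 to compound 3 (0.92 log units; beyond the scatter): a smaller group on that carbon went with a higher number. Compound 4 `CC[C@@H](NC(=O)c1ccc(-c2cccc(CN)c2)cc1)[C@@H](Cc1cccc(C(=N)N)c1)C(=O)OC` differs from compound 3 by hydrogen in place of methyl on a saturated chain carbon bound to two saturated chain carbons; read one bond further out, isopropyl becomes ethyl. This cuts the side chain further, in the same direction as the change from cyclohexylmethyl to isopropyl but by a much smaller piece, so a further rise in the number is expected, smaller than an 8.3-fold higher number from compound 2 to compound 3 (0.92 log units; beyond the scatter). A result at the limit cannot be ruled out. For compound 4 the expected value in this assay is 800 nM, within 300 nM to 2500 nM. That amounts to an expected step of a 2.7-fold higher number from compound 3 to compound 4 (0.43 log units; beyond the scatter).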

Compound 4, inhibition constant: 63 nM
Beside the measured number, compound 4's estimate is 13-fold (1.10 log units) above it, outside the stated range (below it).
By their numbers in this assay, from the lowest: compounds 2 and 4 (each within the scatter of the next); then compound 3. At a limit, above all of these: compound 1.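

In this assay, taking one methyl off the isopropyl group gives a 4.8-fold lower number from compound 3 to compound 4 (0.68 log units; beyond the scatter), the opposite direction to an 8.3-fold higher number from compound 2 to compound 3 (0.92 log units; beyond the scatter), so the number does not simply climb as this side chain is cut down. The ethyl and cyclohexylmethyl side chains cannot be told apart on this read-out, given a 1.8-fold higher number from compound 2 to compound 4 (0.24 log units; within the scatter), and among compounds 2, 3 and 4 the isopropyl group of compound 3 is the one that goes against any trend with side chain size. Nothing shown here bears on why the isopropyl compound gives the highest of these three numbers.

On these data alone, whether that higher number belongs to the branched isopropyl group itself remains open, and a straight propyl chain or an isobutyl group on the same carbon would speak to that. Also open, as far as these compounds go, is how far a chain ending in an amine or a carboxylic acid at this position would track the ethyl and cyclohexylmethyl compounds, and whether a cyclopropyl group would behave like isopropyl.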